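This account rests on a few compounds, and the source may have more. Where it says the series, first, only, none or still open, it means among the compounds named here.

In a toxicity assay on NIH3T3 cells (Mus musculus) for cytotoxicity, read by resazurin assay (on this read-out higher numbers stand for an effect only at larger amounts of compound and lower numbers for an effect already at smaller amounts), the series sits at the weak end of the scale. Compound 1 `COC(=O)c1ccc(NCc2cncn2Cc2ccccc2N)cc1-c1ccccc1` gives 25000 nM. Compound 2 `c1ccc(-c2ccc(Cn3cncc3CNc3ccc(-c4ccc[nH]4)c(-c4ccccc4)c3)cc2)cc1` gives only a limit, > 10000 nM, so no number is known for it. Compound 3 `N#Cc1ccc(NCc2cncn2Cc2ccc(-c3ccccc3)cc2N)cc1-c1ccccc1` likewise gives only a limit, > 1000 nM. Among the compounds with values here, compound 2 therefore stands where nothing more than a boundary is set, at the limit of > 10000 nM in this assay, at which 1 of the 3 values shown sits, while one further value sits at the limit of > 1000 nM in this assay, at which 1 of the 3 values shown sits; no measured pair differs in one place, so no step size is known from these three.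

Compound 4 `c1ccc(-c2ccc(Cn3cncc3CNc3ccc(-c4noc5ccccc45)c(-c4ccccc4)c3)cc2)cc1` is the next point of the series. It differs from compound 2 in a single place: a group of 9 heavy atoms (7 carbon, 1 nitrogen, 1 oxygen; one five-membered aromatic ring with 2 hetero atoms, one six-membered aromatic ring of carbon only) in place of a group of 5 heavy atoms (4 carbon, 1 nitrogen; one five-membered aromatic ring with 1 hetero atom), on an aromatic carbon. This change enters at the position ortho to a phenyl group and para to a large group, on an aromatic carbon of a six-membered aromatic ring of carbon only.

Compound 4 is expected to stay at the weak end, with a step that the limit leaves unreadable from compound 2 to compound 4 that is not expected to reach beyond the usual scatter. The estimated value of compound 4 in this assay is 20000 nM, in a range from 5000 nM to 80000 nM, and the assay may well report only a limit again.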

Compound 4, half-maximal effective concentration: > 10000 nM
Compound 4 ended at the assay's limit (the forecaster's own chance of this, stated with the estimate: 60%); the middle value is on the limit's open side.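

Compound 2 and compound 4 both end at a limit rather than a number, so no step between them can be read: the limit of > 10000 nM in this assay, at which 2 of the 4 values shown sit.

The compounds shown leave open whether the group entering in place of 1H-pyrrol-2-yl changes the effect in this assay at all.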